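Compound 3 to compound 4: a pyridin-2-yl replacement

This account rests on a few compounds, and the source may have more. Where it says the series, first, only, none or still open, it means among the compounds named here.

Values in a functional assay on HEK293 cells (Homo sapiens) for cytotoxicity (on this read-out lower numbers stand for higher toxicity in this test and higher numbers for lower toxicity in this test), for the measured compounds:
Compound 1 `COc1ccc([C@H]2CC(=O)N(c3ccccc3)C2)cc1OC1CCCC1` gives > 10000 nM as a limit.
Compound 2 `COc1ccc([C@H]2CC(=O)N(c3ccccc3C)C2)cc1OC1CCCC1` gives > 10000 nM as a limit.
Compound 3 `COc1ccc([C@H]2CC(=O)N(c3ccc(C(F)(F)F)cc3)C2)cc1OC1CCCC1` gives > 10000 nM as a limit.

Compound 3 stands at > 10000 nM in this assay and this is a limit and not a number. The change to compound 4 `COc1ccc([C@H]2CC(=O)N(c3ccccn3)C2)cc1OC1CCCC1` is pyridin-2-yl in place of 4-(trifluoromethyl)phenyl on an amide-type nitrogen in a ring and it puts pyridin-2-yl in place of 4-(trifluoromethyl)phenyl on an amide-type nitrogen in a ring. The measured steps that bear on it are a step that the two limits leave unreadable from compound 1 to compound 3 and a step that the two limits leave unreadable from compound 2 to compound 3 and a step that the two limits leave unreadable from compound 1 to compound 2 and none of them has a readable size. Compound 1, compound 2 and compound 3 all sit at the limit of > 10000 nM in this assay, at which 3 of the 3 values shown sit, so no step beyond the scatter is expected in either direction. The expected step is a step that the limit leaves unreadable from compound 3 to compound 4 and it remains an estimate. A report of compound 4 as a limit is also the likely outcome. For compound 4 the estimated value is 20000 nM with an expected range from 10000 nM to 50000 nM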

Compound 4, half-maximal cytotoxic concentration: > 10000 nM
Compound 4: only a limit was reported (the forecaster's own chance of this, stated with the estimate: 90%); the middle value does not contradict the limit.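

Compound 4, like compound 1, compound 2 and compound 3, is reported only as a limit in this assay, so no step among these compounds can be read: the limit of > 10000 nM in this assay, at which 4 of the 4 values shown sit.

The compounds shown leave open where any of them truly stands in this assay and whether the group on the amide-type nitrogen changes that read-out at all.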